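The compounds below may be only part of what the source reports. "The series", "measured", "known", "first", "only" and "open" are said of these compounds alone.

Measured so far:
- compound 1, `Fc1cc(F)cc(-c2nc(N3CCN(c4ncccc4C(F)(F)F)CC3)[nH]c2-c2ccc(C(F)(F)F)cc2)c1`: 35 nM in a functional assay on CHO cells for antagonist activity at transient receptor potential cation channel subfamily V member 1 (Rattus norvegicus), read by calcium flux; a lower number here means a stronger inhibitor, a higher number a weaker inhibitor
- compound 2, `Cc1nc(N2CCN(c3ncccc3C(F)(F)F)CC2)[nH]c1-c1ccc(C(F)(F)F)cc1`: 628 nM in this assay

Compound 2 gives the highest number of the two measured; its nearest neighbour is compound 1, and the step of an 18-fold higher number from compound 1 to compound 2 (1.25 log units; beyond the scatter) is large and beyond the scatter. Compound 3, `COC(=O)c1nc(N2CCN(c3ncccc3C(F)(F)F)CC2)[nH]c1-c1ccc(C(F)(F)F)cc1`, has not yet been measured in this assay. It differs from compound 2 in one place: methoxycarbonyl in place of methyl on an aromatic carbon.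

For the measured compounds named here, only one measured step exists, and it exchanges a 3,5-difluorophenyl group for methyl at this same aromatic carbon; it says that a larger group here gave a markedly lower number. Methoxycarbonyl is neither methyl nor 3,5-difluorophenyl, so that step bears on the change only loosely. Going by the values given here, no step with an ester at this carbon is available. For compound 3 the expected step is a 1.6-fold lower number from compound 2 to compound 3 (0.20 log units; within the scatter), that is, within the scatter or a modest lowering. The estimate for compound 3 in this assay is 400 nM, with a range from 100 nM to 1600 nM.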

Compound 3, half-maximal inhibitory concentration: 1170 nM
Estimate against measurement, compound 3: 2.9-fold (0.47 log units) below; low and high end bracket the measured number.
By their numbers in this assay, from the lowest: compound 1; then compounds 2 and 3 (each within the scatter of the next).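

In this assay, methoxycarbonyl in place of methyl on this aromatic carbon gives a 1.9-fold higher number from compound 2 to compound 3 (0.27 log units; within the scatter), so the added heavy atoms and hydrogen-bond acceptors do not separate these two compounds. Of the three groups seen at this carbon, only 3,5-difluorophenyl gives a low number, with a 33-fold higher number from compound 1 to compound 3 (1.52 log units; beyond the scatter) standing alongside an 18-fold higher number from compound 1 to compound 2 (1.25 log units; beyond the scatter), so a greater heavy-atom count than methyl does not by itself bring the number down towards that of compound 1. No measurement is available that would explain the behaviour of these groups at this carbon.

From the compounds shown here alone, it remains open whether an unsubstituted phenyl ring would keep the number of compound 1, or whether the two fluorines are needed. A carboxylic acid or a primary amide at this carbon would show whether other carbonyl groups behave like methoxycarbonyl.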